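This account rests on a few compounds, and the source may have more. Where it says the series, first, only, none or still open, it means among the compounds named here.

In a functional assay on C8166 cells (Homo sapiens) for antiproliferative activity, read by MTT assay (on this read-out higher numbers stand for lower toxicity in this test and lower numbers for higher toxicity in this test), compound 1 `Cc1cc(C)cc(S(=O)(=O)c2c(C(=O)NN3CCOC3=O)[nH]c3ccc(Cl)cc23)c1` gives > 100 uM, which is a limit of the assay and not a number. Compound 2 `CNNC(=O)c1[nH]c2ccc(Cl)cc2c1S(=O)(=O)c1cc(C)cc(C)c1` gives > 100 uM, which is also a limit. The record so far is therefore (the limit of > 100 uM in this assay, at which 2 of the 2 values shown sit). Compound 3 `CC(=O)NNC(=O)c1[nH]c2ccc(Cl)cc2c1S(=O)(=O)c1cc(C)cc(C)c1` keeps the core of compound 1 and changes one group: acetamido in place of 2-oxo-1,3-oxazolidin-3-yl on an amide-type nitrogen. In words, acetamido takes the place of 2-oxo-1,3-oxazolidin-3-yl on an amide-type nitrogen. For the measured compounds named here, the only measured step at this place is a step that the two limits leave unreadable from compound 1 to compound 2, where methylamino is the incoming group, so it offers no size to carry over. With no readable step to build on, no change beyond the usual scatter is expected in this assay, in either direction, and another limit is the likely report. The expected step is a number no higher from compound 1 to compound 3 (the limit leaves the size open). For compound 3 the estimated value is 100 uM, with an expected range from 40 uM to 200 uM.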

Compound 3, half-maximal toxic concentration: > 100 uM
Compound 3 ended at the assay's limit (the forecaster's own chance of this, stated with the estimate: 80%); the middle value lies on the limit itself.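

Compound 3 also ends at a limit of the assay, so its steps from compound 1 and from compound 2 cannot be read, and the record now stands as follows: the limit of > 100 uM in this assay, at which 3 of the 3 values shown sit.

The compounds shown leave open whether the groups on the amide-type nitrogen differ in toxicity at all.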